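The source may hold more compounds than are shown below. What is called first, only, known or untested is meant among the compounds shown, and "the series" means these compounds.

Compound 1 `CCOC(=O)C[C@H]1[C@@H](O[Si](C)(C)C(C)(C)C)[C@H](n2cnc3c(NC(=O)Nc4ccccc4)ncnc32)O[C@@H]1COC(=O)NC` gives 4.95 nM in a functional assay on T47D cells (Homo sapiens) for antiproliferative activity; a lower number here means a stronger inhibitor of growth, a higher number a weaker inhibitor of growth. Compound 2 `CNC(=O)NC[C@H]1O[C@@H](n2cnc3c(NC(=O)Nc4ccccc4)ncnc32)[C@H](O[Si](C)(C)C(C)(C)C)[C@@H]1CC(=O)N(C)OC` gives 13.9 nM in this assay.

Among the measured compounds shown here, of the two numbers known, compound 2 stands highest; its nearest neighbour is compound 1, whose number lies lower by a gap beyond the scatter of repeated measurements. The unmeasured compound 3 `CCOC(=O)C[C@H]1[C@@H](O[Si](C)(C)C(C)(C)C)[C@H](n2cnc3c(NC(=O)Nc4ccccc4)ncnc32)O[C@@H]1CNC(=O)NC` differs from compound 2 at one place: ethoxy in place of methoxy(methyl)amino on a carbonyl carbon. Cut one bond further out, the chain carrying it reads as (ethoxycarbonyl)methyl in compound 3 where compound 2 carries (methoxy(methyl)carbamoyl)methyl. For the measured compounds named here, no measured pair shows this change on its own, so the size of its step is not known from the data. Compound 1 carries the same ethoxycarbonyl group and gives 4.95 nM, which points toward a lower number for compound 3. A modest downward step is expected: a 2.0-fold lower number from compound 2 to compound 3 (0.30 log units; within the scatter). Compound 3 is therefore estimated at 7 nM, within 3 nM to 18 nM.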

Compound 3, concentration for 50% growth inhibition: 2.55 nM
Compound 3: middle estimate off by 2.7-fold (0.44 log units), on the high side; measured number below the stated range.
By their numbers in this assay, from the lowest: compounds 3 and 1 (each within the scatter of the next); then compound 2.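

In this assay, ethoxy in place of methoxy(methyl)amino on a carbonyl carbon can now be read on its own, and it gives a 5.5-fold lower number from compound 2 to compound 3 (0.74 log units; beyond the scatter), so a single change at this place moves the number by more than repeat measurements would. The second single change, (methylcarbamoyl)amino in place of (methylcarbamoyl)oxy on a saturated chain carbon bound to a saturated ring carbon, gives a 1.9-fold lower number from compound 1 to compound 3 (0.29 log units; within the scatter), so that exchange cannot be told apart from the scatter.

From the compounds shown here alone, it remains open whether the ethoxy change carries the same size of step in compounds bearing (methylcarbamoyl)oxy. Going by these compounds, it is also open how a free carboxylic acid, a primary amide or a longer alkoxy chain on the same carbonyl carbon would compare. Nothing in the data shown accounts for the size of the step.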